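Anilino-substituted series, one numbered value and two limits

This account rests on a few compounds, and the source may have more. Where it says the series, first, only, none or still open, it means among the compounds named here.

compound 1 `Fc1cccc(Nc2nc(-c3cccc(F)c3)nc3ccc(F)cc23)c1` — 48700 nM
compound 2 `Fc1cccc(-c2nc(Nc3cccc(Cl)c3)c3cc(F)ccc3n2)c1` — > 50000 nM
compound 3 `Fc1cccc(-c2nc(Nc3ccccc3Br)c3cc(F)ccc3n2)c1` — > 50000 nM

For the measured compounds named here, in a functional assay on MCF7 cells (Homo sapiens) for cytotoxicity, read by MTT assay, with a stated time of 48 h (a higher number here means a weaker inhibitor, a lower number a stronger inhibitor), compound 1 gives 48700 nM, the only numbered value in the set. Compound 2 reaches only the limit of the assay, > 50000 nM. Compound 3 likewise sits at the limit, > 50000 nM. The change from compound 1 to compound 2, chloro in place of fluoro on an aromatic carbon, reads an at least 1.0-fold higher number from compound 1 to compound 2 (0.01 log units; that floor lies within the scatter). The change from compound 1 to compound 3, 2-bromophenyl in place of 3-fluorophenyl on a nitrogen on an aromatic ring, reads an at least 1.0-fold higher number from compound 1 to compound 3 (0.01 log units; that floor lies within the scatter). Between compound 2 and compound 3 the step is a step that the two limits leave unreadable from compound 2 to compound 3, since both values are limits (the limit of > 50000 nM in this assay, at which 2 of the 3 values shown sit).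

Compound 4 `Nc1ccc(Nc2nc(-c3cccc(F)c3)nc3ccc(F)cc23)cc1` differs from compound 1 by 4-aminophenyl in place of 3-fluorophenyl on a nitrogen on an aromatic ring. Going by the values given here, the only measured step at this same position, from compound 1 to compound 3, is confined to a floor within the scatter, and no measured step carries an aminophenyl group, so the direction is not set by the data. Compound 4 is expected near compound 1, the estimated step being a 1.2-fold lower number from compound 1 to compound 4 (0.09 log units; within the scatter). Compound 4 is therefore estimated at 40000 nM, with a range from 15000 nM to 100000 nM, and a fair chance that only a limit is recorded.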

Compound 4, half-maximal inhibitory concentration: > 50000 nM
Compound 4 was reported as a limit; the forecaster's own chance of this, stated with the estimate: 45%; middle value at least 1.2-fold (0.09 log units) from the limit.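

In this assay the change to 4-aminophenyl on the nitrogen reads an at least 1.0-fold higher number from compound 1 to compound 4 (0.01 log units; that floor lies within the scatter), so an amino-bearing phenyl group, with its hydrogen-bond donor and acceptor, gives no step beyond the scatter, as with the 2-bromophenyl of compound 3. Compound 4 is recorded only as a limit, > 50000 nM, and the steps linking it to compound 2 and compound 3 cannot be read. The series now holds halogen-bearing and amino-bearing phenyl groups at this position, with no number set apart from the assay ceiling: the limit of > 50000 nM in this assay, at which 3 of the 4 values shown sit.

As far as these compounds go, how far compound 2, compound 3 and compound 4 lie past that limit stays open. The compounds shown also leave open whether a carboxylic acid on this phenyl ring, or a longer chain ending in an amine in its place, would bring a value under the limit.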